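From an ether to a bulkier ester on the shared core

The compounds below may be only part of what the source reports. "The series", "measured", "known", "first", "only" and "open" are said of these compounds alone.

Measured so far in a functional assay on A549 cells (Homo sapiens) for cytotoxicity, with a stated time of 48 h; on this read-out lower numbers stand for stronger inhibition and higher numbers for weaker inhibition:
- compound 1, `CCOc1ccc2oc(/C=C/[S+](C)[O-])cc(=O)c2c1`: 1500 nM
- compound 2, `CC(C)COc1ccc2oc(/C=C/[S+](C)[O-])cc(=O)c2c1`: 1100 nM
- compound 3, `CCCC(=O)Oc1ccc2oc(/C=C/[S+](C)[O-])cc(=O)c2c1`: 2200 nM

All three compounds share one core and differ only in the group on an oxygen on an aromatic ring. Compound 2 sits among three numbers that are all within the scatter of one another: the change a 1.4-fold lower number from compound 1 to compound 2 (0.13 log units; within the scatter) and the change a 2.0-fold higher number from compound 2 to compound 3 (0.30 log units; within the scatter) are both too small to count as real differences, as is a 1.5-fold higher number from compound 1 to compound 3 (0.17 log units; within the scatter).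

Compound 4, `C[S+]([O-])/C=C/c1cc(=O)c2cc(OC(=O)C(C)(C)C)ccc2o1`, is not yet measured. Relative to compound 2 it carries (tert-butyl)carbonyl in place of isobutyl on an oxygen on an aromatic ring.

The measured step that comes closest to this change is the one from an ether to an ester, seen in a 2.0-fold higher number from compound 2 to compound 3 (0.30 log units; within the scatter), which stayed within the scatter. Among the compounds with values here, no measured pair shows the branched (tert-butyl)carbonyl group itself, so the expectation rests on that single ester step alone.

Compound 4 is therefore expected to give 2000 nM in this assay, within a range from 900 nM to 4500 nM. The estimated step of a 1.8-fold higher number from compound 2 to compound 4 (0.26 log units; within the scatter) is expected to be small, at most at the edge of the scatter, toward a somewhat higher number.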

Compound 4, half-maximal inhibitory concentration: 1600 nM
For compound 4 the middle estimate is 1.3-fold (0.10 log units) above the measured one; measured number inside the range.
By their numbers in this assay, from the lowest: compounds 2, 1, 4 and 3 (each within the scatter of the next).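

In this assay the branched ester stays close to both ethers: the change is a 1.5-fold higher number from compound 2 to compound 4 (0.16 log units; within the scatter) against the isobutyl ether and a 1.1-fold higher number from compound 1 to compound 4 (0.03 log units; within the scatter) against the ethyl ether. Within the data shown here, compound 4 also allows something the earlier compounds did not, a comparison of two esters that differ only in the group on the carbonyl carbon, and that change is a 1.4-fold lower number from compound 3 to compound 4 (0.14 log units; within the scatter) for tert-butyl in place of propyl. Across these four compounds, then, neither changing the link on the oxygen on an aromatic ring from ether to ester nor branching the ester chain moves the number beyond the usual scatter, so no group here stands apart from the others.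

Going by these compounds, whether a free hydroxyl group, a much longer chain such as octyl, or an amine at the end of the chain would shift the number beyond the scatter at this oxygen remains open. Nothing available here explains why these four groups give such similar numbers.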